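Methoxy in place of chloro on compound 1

The source may hold more compounds than are shown below. What is called first, only, known or untested is meant among the compounds shown, and "the series" means these compounds.

Compound 1 `CC(C)N1C(=O)COc2ccc(-c3cnc(Cl)c(NS(=O)(=O)c4ccc(F)cc4)c3)cc21` gives 5100 nM in a functional assay on A549 cells (Homo sapiens) for antiproliferative activity, read by MTT assay, with a stated time of 72 h; a higher number here means a weaker inhibitor, a lower number a stronger inhibitor. Two close relatives frame that number. Compound 3 `O=C1COc2ccc(-c3cnc(Cl)c(NS(=O)(=O)c4ccc(F)cc4)c3)cc2N1C1CC1` gives 4330 nM, and the step is a 1.2-fold lower number from compound 1 to compound 3 (0.07 log units; within the scatter), so the two stand level. Compound 2 `Cc1ccc(N2C(=O)COc3ccc(-c4cnc(Cl)c(NS(=O)(=O)c5ccc(F)cc5)c4)cc32)cc1` gives 30900 nM, and the step here is a 6.1-fold higher number from compound 1 to compound 2 (0.78 log units; beyond the scatter). Compound 1 thus sits level with compound 3, and compound 2 has the clearly higher number, with a further step of a 7.1-fold lower number from compound 2 to compound 3 (0.85 log units; beyond the scatter).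

Compound 4 `COc1ncc(-c2ccc3c(c2)N(C(C)C)C(=O)CO3)cc1NS(=O)(=O)c1ccc(F)cc1` keeps the isopropyl of compound 1 and changes a different place: methoxy in place of chloro on an aromatic carbon. This puts methoxy in place of chloro on an aromatic carbon, next to the ring nitrogen. All three measured steps vary the group on the amide-type nitrogen, and none touches this carbon, so they bear on the new change only indirectly. They show how far the series can move at another place, as in a 6.1-fold higher number from compound 1 to compound 2 (0.78 log units; beyond the scatter), but they give neither size nor direction for this swap. No step beyond the scatter is therefore expected in this assay, although the uncertainty stays wide. The expected step is a 1.5-fold lower number from compound 1 to compound 4 (0.16 log units; within the scatter). For compound 4 the estimated value is 3500 nM, with an expected range of 800 nM to 14000 nM.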

Compound 4, half-maximal inhibitory concentration: 4920 nM
Beside the measured number, compound 4's estimate is 1.4-fold (0.15 log units) below it; low and high end bracket the measured number.
By their numbers in this assay, from the lowest: compounds 3, 4 and 1 (each within the scatter of the next); then compound 2.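

In this assay the carbon next to the ring nitrogen now has a direct reading: methoxy in place of chloro gives a 1.0-fold lower number from compound 1 to compound 4 (0.02 log units; within the scatter) and leaves the two compounds level. The earlier steps shown here varied only the group on the amide-type nitrogen, where a change can move the number beyond the scatter, as in a 6.1-fold higher number from compound 1 to compound 2 (0.78 log units; beyond the scatter) and no such movement appears at this carbon in this single pair, even though methoxy counts a hydrogen-bond acceptor and chloro does not. No measurement shown here bears on why the number holds across this swap.

As far as these compounds go, the reading rests on one pair with isopropyl on the amide-type nitrogen, so it remains open whether methoxy would also leave the number level with the cyclopropyl of compound 3 or the 4-methylphenyl of compound 2 in that place. From the compounds shown here alone, it is also open how this carbon would respond to an amine, a carboxylic acid or a longer chain such as butoxy, any of which could show whether the level result extends beyond these two groups.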